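Swapping Benzyl for Pyridin-3-yl in a Weak Series

The compounds below may be only part of what the source reports. "The series", "measured", "known", "first", "only" and "open" are said of these compounds alone.

Compound 1, `CCCCCCCCCCCCCCCCCCNC(=O)[C@H]1CSC(C2CCCCC2)N1`, reaches only the assay limit > 20000 nM in a functional assay on TSU-Pr1 cells for antiproliferative activity against TSU (Homo sapiens), read by sulforhodamine B assay; a lower number here means a stronger inhibitor, a higher number a weaker inhibitor.
Compound 2, `CCCCCCCCCCCCCCCCCCNC(=O)[C@H]1CSC(Cc2ccccc2)N1`, gives 11200 nM in this assay.

Among the measured compounds shown here, compound 2 thus holds the only real number among the two values shown; the other value is a limit, as the limit of > 20000 nM in this assay, at which 1 of the 2 values shown sits, records. For the measured compounds named here, the single measured step, an at least 1.7-fold lower number from compound 1 to compound 2 (0.25 log units; that floor lies within the scatter), has a floor that lies within the usual scatter, so it gives no firm direction.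

Compound 3, `CCCCCCCCCCCCCCCCCCNC(=O)[C@H]1CSC(c2cccnc2)N1`, differs from compound 2 by pyridin-3-yl in place of benzyl on a saturated ring carbon. Going by the values given here, no measured step exchanges benzyl for an aromatic ring attached directly to that saturated ring carbon, so the expectation rests only on the weak level of compound 2 and on the small size of the one measured step. Compound 3 is therefore expected to stay near compound 2, at about 13000 nM, within 4000 nM to 40000 nM. That estimate means a 1.2-fold higher number from compound 2 to compound 3 (0.06 log units; within the scatter), a step not expected to exceed the scatter.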

Compound 3, half-maximal inhibitory concentration: 7800 nM
Beside the measured number, compound 3's estimate is 1.7-fold (0.22 log units) above it; the range from low to high includes it.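

Pyridin-3-yl and benzyl on this saturated ring carbon cannot be told apart in this assay, with a 1.4-fold lower number from compound 2 to compound 3 (0.16 log units; within the scatter), so an aromatic ring attached directly to that carbon and carrying a ring nitrogen keeps the level of compound 2. The comparison with cyclohexyl is firmer, with an at least 2.5-fold lower number from compound 1 to compound 3 (0.40 log units; beyond the scatter), and this is the first step shown that clears the scatter, though only modestly. That step is only a floor, as compound 1 gives a limit and not a number: the limit of > 20000 nM in this assay, at which 1 of the 3 values shown sits.

The swap changes two things at once, adding a ring nitrogen and removing the carbon that links the ring, and only phenyl on this ring carbon could separate the two. On these data alone, whether an amine, a carboxylic acid or a shorter chain in place of the long one lifts the series out of its weak range stays open.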